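This account rests on a few compounds, and the source may have more. Where it says the series, first, only, none or still open, it means among the compounds named here.

Working notes on the series. In a functional assay on MCF7 cells (Homo sapiens) for inhibition (on this read-out higher numbers stand for weaker inhibition of growth and lower numbers for stronger inhibition of growth), compound 1 `O=C1CC[C@@H](COC(=O)c2ccsc2NC(=O)[C@@H]2CCCN2)N1` gives 148 ug/mL, the lowest of the two numbers shown. Compound 2 `O=C(OC1CCCCC1)c1ccsc1NC(=O)[C@@H]1CCCN1` gives 162 ug/mL, and the step is a 1.1-fold higher number from compound 1 to compound 2 (0.04 log units; within the scatter). Compound 3 `O=C(OCc1ccccc1)c1ccsc1NC(=O)[C@@H]1CCCN1` gives only a limit of the assay, > 250 ug/mL; this is the limit of > 250 ug/mL in this assay, at which 1 of the 3 values shown sits. The steps towards it are an at least 1.6-fold higher number from compound 1 to compound 3 (0.22 log units; that floor lies within the scatter) and an at least 1.5-fold higher number from compound 2 to compound 3 (0.18 log units; that floor lies within the scatter). Compound 4 `O=C(Oc1ccccc1)c1ccsc1NC(=O)[C@@H]1CCCN1` is not yet measured; it differs from compound 1 in that (phenyl in place of (5-oxopyrrolidin-2-yl)methyl on an oxygen next to a carbonyl group). The two steps towards compound 3 bear most on this, since there phenyl also entered and both numbers rose, though only to a limit. In this assay a step of a 1.4-fold higher number from compound 1 to compound 4 (0.15 log units; within the scatter) is therefore expected, towards weaker inhibition of growth or none beyond the scatter, with a fair chance of a limit. The estimate for compound 4 is 210 ug/mL, within 120 ug/mL to 400 ug/mL.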

Compound 4, concentration for 50% growth inhibition: > 250 ug/mL
Compound 4: no number, only a limit; the forecaster's own chance of this, stated with the estimate: 35%; at least 1.1-fold (0.07 log units) between middle value and limit.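

In this assay, phenyl on an oxygen next to a carbonyl group gives a limit and no number, as benzyl did, so both groups with an aromatic ring shown at this place end at the limit: the limit of > 250 ug/mL in this assay, at which 2 of the 4 values shown sit.

Against the two groups with numbers, the steps are an at least 1.6-fold higher number from compound 1 to compound 4 (0.22 log units; that floor lies within the scatter) and an at least 1.5-fold higher number from compound 2 to compound 4 (0.18 log units; that floor lies within the scatter). The step between compound 3 and compound 4 cannot be read.

Where compound 3 and compound 4 truly lie stays open, so any real gap from compound 1 and compound 2 is unsettled. On these data alone, what an amine or a carboxylic acid at this place would give also stays open.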